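Fluorinated piperazine aryl variants of the aminothiophene series

This account rests on a few compounds, and the source may have more. Where it says the series, first, only, none or still open, it means among the compounds named here.

Measured so far:
compound 1 `Nc1scc(CN2CCN(c3ccccc3C(F)(F)F)CC2)c1C(=O)c1ccc(Cl)cc1`, -7.5%
compound 2 `Nc1scc(CN2CCN(c3cccc(F)c3)CC2)c1C(=O)c1ccc(Cl)cc1`, -37%

In a functional assay on CHO cells with adenosine receptor A1 (Homo sapiens) as the target, read by cAMP accumulation and immunoassay, with a stated time of 6 min, tested at 0.1 uM (on this read-out lower numbers stand for a stronger effect and higher numbers for a weaker effect at the one concentration tested), compound 1 gives -7.5% and compound 2 gives -37%. Compound 2 stands lowest of the two numbers; its nearest neighbour is compound 1, which lies higher by a number 29.5 percentage points lower from compound 1 to compound 2 (beyond the scatter), a modest step beyond the scatter, obtained with 3-fluorophenyl in place of 2-(trifluoromethyl)phenyl on the amine nitrogen in the ring.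

Compound 3 `Nc1scc(CN2CCN(c3ccc(F)c(F)c3)CC2)c1C(=O)c1ccc(Cl)cc1` differs from compound 2 by fluoro in place of hydrogen on an aromatic carbon. Among the measured compounds shown here, no measured step covers the addition of a second fluoro to the 3-fluorophenyl ring; the one step on hand, a number 29.5 percentage points lower from compound 1 to compound 2 (beyond the scatter), changes the aryl group altogether and so bears only loosely on this change. With nothing pointing in either direction, the expected step from compound 2 to compound 3 is a number 1 percentage points lower from compound 2 to compound 3 (within the scatter), within the scatter. Compound 3 is therefore estimated at -38%, with a range from -62% to -14%.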

Compound 3, a percentage reported as activity, at one concentration (the size of the read-out at that concentration, not a potency): -34%
Compound 3: the middle estimate sits 4 percentage points below what was measured, and the stated range covers the measured number.
By their numbers in this assay, from the lowest: compounds 2 and 3 (each within the scatter of the next); then compound 1.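

In this assay, fluoro at this position, ortho to a fluoro group and para to a large group, turns 3-fluorophenyl into 3,4-difluorophenyl and gives a number 3 percentage points higher from compound 2 to compound 3 (within the scatter) with no change that can be separated from the scatter, so the position accepts this second fluoro with the read-out held. The 3,4-difluorophenyl group also stands apart from 2-(trifluoromethyl)phenyl, with a number 26.5 percentage points lower from compound 1 to compound 3 (beyond the scatter) as the step, so the gap seen with compound 2 is not confined to the 3-fluorophenyl group. No supporting data on hand explain either step.

Open, on these data alone, is whether this tolerance extends beyond fluoro to a larger group at the same position, such as chloro, methoxy or an amine. Also open is whether the read-out at this single concentration reflects any difference in potency among these compounds.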